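Swapping an aryl group on a thiourea-containing scaffold

This account rests on a few compounds, and the source may have more. Where it says the series, first, only, none or still open, it means among the compounds named here.

Compound 1 `COc1cc(/C=C/C(=O)C2=C(/C=C/c3ccc(O)c(OC)c3)NC(=O)NC2c2ccc(C)cc2)ccc1O` and compound 2 `COc1cc(/C=C/C(=O)C2=C(/C=C/c3ccc(O)c(OC)c3)NC(=O)NC2c2ccccc2O)ccc1O` share a core and differ only where compound 2 carries 2-hydroxyphenyl in place of 4-methylphenyl on a saturated ring carbon. In a functional assay on QG-56 cells (Homo sapiens) for cytotoxicity, read by MTT assay, with a stated time of 48 h (a higher number here means a weaker inhibitor, a lower number a stronger inhibitor), compound 1 gives 100000 nM and compound 2 gives 100000 nM, so no change at the digits printed from compound 1 to compound 2 (within the scatter). Compound 3 `COc1cc(/C=C/C(=O)C2=C(/C=C/c3ccc(O)c(OC)c3)NC(=S)NC2c2ccc(C)cc2)ccc1O` has a different core; how the two cores differ is not broken down here. In this assay compound 3 gives 12500 nM, the strongest of the three measured compounds. Compound 4 `COc1cc(/C=C/C(=O)C2=C(/C=C/c3ccc(O)c(OC)c3)NC(=S)NC2c2ccccc2O)ccc1O` is made from compound 3 by the same change, (2-hydroxyphenyl in place of 4-methylphenyl on a saturated ring carbon), at the same place as before. Because no change at the digits printed from compound 1 to compound 2 (within the scatter) showed no shift, the step from compound 3 to compound 4 is expected to be small as well, estimated at no change at the digits printed from compound 3 to compound 4 (within the scatter). Compound 4 is therefore estimated to give 12500 nM, with a likely range from 5000 nM to 35000 nM.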

Compound 4, half-maximal inhibitory concentration: 50000 nM
For compound 4 the middle estimate is 4.0-fold (0.60 log units) below the measured one; the measured number lies above the stated range.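

Putting 2-hydroxyphenyl in place of 4-methylphenyl in this assay gives a 4.0-fold higher number from compound 3 to compound 4 (0.60 log units; beyond the scatter). The same change therefore does not behave alike on the two cores: the same change on two cores in this assay, no change at the digits printed (within the scatter) from compound 1 to compound 2 and a 4.0-fold higher number (0.60 log units; beyond the scatter) from compound 3 to compound 4, 4.0-fold (0.60 log units) apart, beyond the scatter of two such steps. For the compounds shown here, this comparison rests on only two steps in one cell assay, so it shows that the size of the step can differ with the core, but not why it differs or how it would go on any further core.

The compounds shown leave open how a phenyl ring carrying an amine or a carboxylic acid would behave on the saturated ring carbon of either core. They also leave open whether the two cores would differ in the same way in other cell lines.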